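The source may report more compounds than this note shows. Statements on the series, on what has been measured and on what is new or still open speak of the compounds shown alone.

Working notes on the acyl sulfonamide series. In an ADME assay on the whole organism (Macaca fascicularis) for pharmacokinetics, at a dose of 1 mg/kg by the oral route (on this read-out higher numbers stand for higher exposure at the dose given and lower numbers for lower exposure), compound 1 `Cc1sc(N(CC2CC2)[C@H](C)c2ccc(-c3cc(Cl)ccc3-c3nc(=O)o[nH]3)cc2)nc1C(=O)O` gives 1260 nM, compound 2 `Cc1sc(N(CC2CC2)[C@H](C)c2ccc(-c3cc(Cl)ccc3-c3nc(=O)o[nH]3)cc2)nc1C(=O)NS(C)(=O)=O` gives 367 nM and compound 3 `CCS(=O)(=O)NC(=O)c1nc(N(CC2CC2)[C@H](C)c2ccc(-c3cc(Cl)ccc3-c3nc(=O)o[nH]3)cc2)sc1C` gives 1190 nM. Compound 3 stands second highest of the three, within the scatter of compound 1 and well clear of compound 2. Compound 4 `Cc1sc(N(CC2CC2)[C@H](C)c2ccc(-c3cc(Cl)ccc3-c3nc(=O)o[nH]3)cc2)nc1C(=O)NS(=O)(=O)C1CC1` carries cyclopropyl in place of ethyl on a sulfonyl sulfur. Among the compounds with values here, the one step that bears on it is growth of the sulfonyl substituent, a 3.2-fold higher number from compound 2 to compound 3 (0.51 log units; beyond the scatter), while a 1.1-fold lower number from compound 1 to compound 3 (0.02 log units; within the scatter) and a 3.4-fold lower number from compound 1 to compound 2 (0.54 log units; beyond the scatter) show the acid itself is not bettered. A further one-carbon growth in this assay is expected to give at most a small rise, a 1.2-fold higher number from compound 3 to compound 4 (0.07 log units; within the scatter), likely within the scatter. Compound 4 is therefore estimated at 1400 nM, range 550 nM to 3500 nM.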

Compound 4, maximal plasma concentration: 1970 nM
Compound 4: middle estimate off by 1.4-fold (0.15 log units), on the low side; the range from low to high includes it.
By their numbers in this assay, from the lowest: compound 2; then compounds 3, 1 and 4 (each within the scatter of the next).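

On the sulfonyl sulfur, cyclopropyl in place of ethyl leaves the exposure within the scatter in this assay (a 1.7-fold higher number from compound 3 to compound 4 (0.22 log units; within the scatter)). Cyclopropyl in place of methyl gives a step beyond the scatter (a 5.4-fold higher number from compound 2 to compound 4 (0.73 log units; beyond the scatter)), so the cyclopropyl compound sits with the ethyl compound, clear of the methyl compound, and within the scatter of the parent acid (a 1.6-fold higher number from compound 1 to compound 4 (0.19 log units; within the scatter)). Nothing among the data explains these exposures. As far as these compounds go, whether isopropyl, tert-butyl or phenyl on the sulfonyl sulfur stays at this level remains open.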